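Replacing hexyl with 1-cyclohexylethyl on the urea nitrogen

A few compounds are considered here, and "the series" means these few. Any claim that something is new, unique, unknown or untested is made for them only; others in the source may bear on it.

In an assay on membranes from Sf9 cells for displacement of a labelled ligand from histamine H2 receptor (Homo sapiens), read by scintillation counting, with a stated time of 60 min (a higher number here means a weaker inhibitor, a lower number a stronger inhibitor), compound 2 `CCCCCCNC(=O)/N=C(\N)NCCCc1sc(N)nc1C` gives 28.8 nM, the lowest of the three numbers measured. Compound 1 `Cc1nc(N)sc1CCCN/C(N)=N/C(=O)N[C@@H](C)c1ccccc1` gives 51.3 nM and compound 3 `Cc1nc(N)sc1CCCN/C(N)=N/C(=O)NC(C)c1cccs1` gives 63.1 nM. The step of a 1.8-fold lower number from compound 1 to compound 2 (0.25 log units; within the scatter) and the step of a 2.2-fold higher number from compound 2 to compound 3 (0.34 log units; beyond the scatter) bracket what a branched 1-substituted ethyl group in place of hexyl has done so far. Compound 4 `Cc1nc(N)sc1CCCN/C(N)=N/C(=O)NCC(C)C1CCCCC1` differs from compound 2 by 1-cyclohexylethyl in place of pentyl on a saturated chain carbon bound to an amide-type nitrogen. Both earlier steps bear on this change, and both were small, so compound 4 is expected to give a number in this assay near that of compound 2, with at most a modest move toward a higher number, a 1.4-fold higher number from compound 2 to compound 4 (0.14 log units; within the scatter). Compound 4 is therefore estimated at 40 nM, with a range from 18 nM to 90 nM.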

Compound 4, inhibition constant: 39.8 nM
Beside the measured number, compound 4's estimate is 1.0-fold (0.00 log units) above it, and the stated range covers the measured number.
By their numbers in this assay, from the lowest: compounds 2, 4, 1 and 3 (each within the scatter of the next, the first and the last beyond it).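

Putting 1-cyclohexylethyl in place of pentyl gives a 1.4-fold higher number from compound 2 to compound 4 (0.14 log units; within the scatter) in this assay and so leaves the number essentially unchanged. A group with a six-membered non-aromatic ring of carbon only is thus accommodated here, whereas the earlier ring-bearing groups were 1-phenylethyl and 1-(thiophen-2-yl)ethyl. No measurement available explains this result. Going by these compounds, whether an amine or a carboxylic acid on this chain would keep the number in this range remains open. So does the effect of a chain longer than hexyl.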